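From 4-methoxybenzyl to hexyl: will growth inhibition shift?

The source may hold more compounds than are shown below. What is called first, only, known or untested is meant among the compounds shown, and "the series" means these compounds.

In a functional assay on K562 cells (Homo sapiens) for inhibition, read by fluorescence, with a stated time of 72 h (on this read-out higher numbers stand for weaker inhibition of growth and lower numbers for stronger inhibition of growth), compound 1 (`COc1ccc(Cn2cnc3c(Nc4cccc(Cl)c4)nc(N[C@H]4CC[C@H](N)CC4)nc32)cc1`) gives 2800 nM. Two relatives share its core but differ from it in more than one place: compound 2 (`CCCCn1cnc2c(NCc3cccc(Cl)c3)nc(N[C@H]3CC[C@H](N)CC3)nc21`) gives 4300 nM, and compound 3 (`COc1cc(Nc2nc(N[C@H]3CC[C@H](N)CC3)nc3c2ncn3CCC(C)C)cc(OC)c1`) gives 2500 nM. All three numbers lie within the usual scatter of one another, so compound 1 stands level with the other two and no ranking among them can be claimed.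

Compound 4 (`CCCCCCn1cnc2c(Nc3cccc(Cl)c3)nc(N[C@H]3CC[C@H](N)CC3)nc21`) keeps the rest of compound 1 and alters a single group: pentyl in place of 4-methoxyphenyl on a saturated chain carbon bound to an aromatic nitrogen. Read one bond further out, this is 4-methoxybenzyl giving way to hexyl.

Going by the values given here, no measured pair isolates a swap of this kind, so direct evidence is missing. The nearest guide is indirect: compound 2 at 4300 nM and compound 3 at 2500 nM also have a ring-free chain on that nitrogen, although they differ elsewhere too. Compound 1, with 2800 nM, sits within the scatter of both. No shift beyond the scatter, in either direction, is therefore expected in this assay. The estimated step is a 1.1-fold higher number from compound 1 to compound 4 (0.03 log units; within the scatter). For compound 4 the estimated value is 3000 nM, with an expected range of 1200 nM to 7500 nM.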

Compound 4, concentration for 50% growth inhibition: 2300 nM
Beside the measured number, compound 4's estimate is 1.3-fold (0.12 log units) above it, within the range that was stated.
By their numbers in this assay, from the lowest: compounds 4, 3, 1 and 2 (each within the scatter of the next).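

Going by these compounds alone, this pair is the first in the set to differ in one place only, so the swap from 4-methoxybenzyl to hexyl can now be read directly: it gives a 1.2-fold lower number from compound 1 to compound 4 (0.09 log units; within the scatter) in this assay and so leaves the two compounds level. At this position, on a saturated chain carbon bound to an aromatic nitrogen, the six-membered aromatic ring with its methoxy group can give way to a ring-free pentyl without a step beyond the scatter, so this ring is not needed to reach the growth inhibition of compound 1. No measurement shown explains why the two compounds stand level.

The compounds shown leave open how this position would respond to a group of another kind, such as an amine or a carboxylic acid at the end of the chain, or to a chain longer than hexyl. They also leave open whether the swap would read the same with other groups elsewhere on the shared core, since compound 2 and compound 3 each differ from compound 1 in more than one place.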